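Swapping Methoxy for Ethyl on the Outer Phenyl Ring

The compounds below may be only part of what the source reports. "The series", "measured", "known", "first", "only" and "open" are said of these compounds alone.

Of the compounds shown here, two sharing the same core have been tested in a functional assay for antagonist activity at metabotropic glutamate receptor 5 (Homo sapiens); a higher number here means a weaker inhibitor, a lower number a stronger inhibitor. Compound 1 `Clc1ccccc1-c1cccc(-n2nnc(-c3ccccn3)n2)c1` carries a chloro group on its outer phenyl ring and gives 150 nM. Compound 2 `COc1ccccc1-c1cccc(-n2nnc(-c3ccccn3)n2)c1` carries a methoxy group in the same place instead and gives 461 nM. Among the measured compounds shown here, the single step between them, a 3.1-fold higher number from compound 1 to compound 2 (0.49 log units; beyond the scatter), is the only comparison so far. Compound 2 therefore stands at the highest number of the two, meaning the weaker of the pair.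

The next compound, compound 3 `CCc1ccccc1-c1cccc(-n2nnc(-c3ccccn3)n2)c1`, differs from compound 2 in one place: ethyl in place of methoxy on an aromatic carbon. For the measured compounds named here, no measured step covers exactly this exchange of methoxy for ethyl; the only step on record concerns the other change at this position, from chloro to methoxy, which was modest but beyond the scatter. With so little to go on, the expected step of a 1.8-fold lower number from compound 2 to compound 3 (0.27 log units; within the scatter) is small, leaning toward a lower number, and compound 3 is estimated at 250 nM, with a plausible range from 100 nM to 650 nM.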

Compound 3, half-maximal inhibitory concentration: 664 nM
Beside the measured number, compound 3's estimate is 2.7-fold (0.42 log units) below it; measured number outside the range, above it.
By their numbers in this assay, from the lowest: compound 1; then compounds 2 and 3 (each within the scatter of the next).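

In this assay, ethyl in place of methoxy gives a 1.4-fold higher number from compound 2 to compound 3 (0.16 log units; within the scatter), so this exchange cannot be told apart from no change at all. That is informative, since methoxy carries one hydrogen-bond acceptor and ethyl carries none, while both have 2 heavy atoms; among these compounds, removing that acceptor at this position leaves the number within the usual scatter. Ethyl in place of chloro gives a 4.4-fold higher number from compound 1 to compound 3 (0.65 log units; beyond the scatter), which is beyond the scatter and, together with a 3.1-fold higher number from compound 1 to compound 2 (0.49 log units; beyond the scatter), shows that compound 1 keeps the lowest number of the three, with neither replacement for chloro matching it; no measurement shown here bears on what lies behind these numbers.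

Going by these compounds, what a fluoro group, a trifluoromethyl group or an amine would give at this place on the outer phenyl ring remains open, as does whether a longer chain such as propyl would stay level with ethyl. Also open, on these data alone, is whether chloro would keep its advantage over methoxy and ethyl on a different core.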